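The compounds below may be only part of what the source reports. "The series", "measured", "known", "first", "only" and "open" are said of these compounds alone.

Working notes on the series.

Among the measured compounds shown here, the two compounds measured so far share the same core and were both tested in an assay on isolated protein for inhibition of ribosomal protein S6 kinase alpha-1 (Homo sapiens), read by mobility shift assay, tested at 30 uM; on this read-out lower numbers stand for less inhibition and higher numbers for more inhibition at the one concentration tested (going by the name of the read-out). Compound 1, `COc1ccc(-c2cc3[nH]nc(N)c3c(=O)[nH]2)cc1`, carries a 4-methoxyphenyl on that core and in this assay compound 1 gives 7%. Compound 2, `CC(C)(C)c1cc2nn(-c3ccccc3)c(N)c2c(=O)[nH]1`, carries a tert-butyl at the same place and a phenyl on the pyrazole nitrogen; in this assay compound 2 gives 5%. On the numbers shown, compound 2 holds the lower of the two values, but the gap to compound 1 lies within the scatter, so the two compounds cannot be told apart on this read-out, and both sit at the low end of the scale.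

Compound 3, `COc1ccccc1-c1cc2nn(-c3ccccc3)c(N)c2c(=O)[nH]1`, keeps the phenyl on the pyrazole nitrogen of compound 2 and differs from compound 2 in one place: 2-methoxyphenyl in place of tert-butyl on an aromatic carbon. For the measured compounds named here, no measured pair reproduces this change, so the step can only be judged from the neighbourhood of low values. Given that compound 1 gives 7% with an aryl group at the same position, a step from compound 2 to compound 3 of a number 3 percentage points higher from compound 2 to compound 3 (within the scatter) is expected, that is none beyond the scatter. For compound 3 the estimate in this assay is 8%, with a range from 0% to 25%.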

Compound 3, a percentage reported as inhibition, at one concentration (the size of the read-out at that concentration, not a potency): 3%
Beside the measured number, compound 3's estimate is 5 percentage points above it; the range from low to high includes it.
By their numbers in this assay, from the lowest: compounds 3, 2 and 1 (each within the scatter of the next).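

Among the compounds shown here, this is the first pair that differs in one place, so the position next to the ring nitrogen can now be read directly, not just inferred from neighbouring compounds. In this assay, 2-methoxyphenyl in place of tert-butyl gives a number 2 percentage points lower from compound 2 to compound 3 (within the scatter), so going from a group of 4 heavy atoms with no ring to one of 8 heavy atoms with a six-membered aromatic ring and 1 hydrogen-bond acceptor does not separate the two compounds on this read-out, and with the phenyl on the nitrogen kept, both stay at the low end of the scale. Nothing available bears on why this exchange leaves the two compounds indistinguishable.

From the compounds shown here alone, only these two groups can be compared at this carbon, so it remains open whether an amine, a carboxylic acid or a longer alkyl chain there would give a step beyond the scatter. No pair shown isolates the phenyl on the nitrogen either, so its contribution cannot be read from these compounds.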